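The compounds below may be only part of what the source reports. "The series", "measured", "known", "first", "only" and "open" are said of these compounds alone.

Measured compounds in an ADME assay on PBMC cells (Homo sapiens) for cytotoxicity, read by MTT assay, with a stated time of 5 days; a higher number here means that more compound is tolerated, a lower number that less compound is tolerated:

Compound 1 `COc1ccc2c(c1)OC(c1cccc([N+](=O)[O-])c1)C(c1ccccc1)C2=O`: a limit of the assay, > 2500000 nM
Compound 2 `COc1ccc2c(c1)OC(c1ccc([N+](=O)[O-])cc1)C(c1ccccc1)C2=O`: 595000 nM
Compound 3 `CCOc1ccc2c(c1)OC(c1cccc([N+](=O)[O-])c1)C(c1ccccc1)C2=O`: a limit of the assay, > 2500000 nM

Among the compounds with values here, compound 2 is the only compound of the three for which this assay returns a number rather than a limit; the other two values sit at the limit of > 2500000 nM in this assay, at which 2 of the 3 values shown sit. Compound 4 `CCOc1ccc2c(c1)OC(c1ccc([N+](=O)[O-])cc1)C(c1ccccc1)C2=O` is the compound still to be measured. It differs from compound 2 by methyl in place of hydrogen on a saturated chain carbon bound to an oxygen on an aromatic ring.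

Within the data shown here, two measured steps touch on this comparison. The move from the 3-nitrophenyl of compound 1 to the 4-nitrophenyl of compound 2 gave an at least 4.2-fold lower number from compound 1 to compound 2 (0.62 log units; beyond the scatter). The very change that leads from compound 2 to compound 4, a methyl in place of hydrogen on the saturated chain carbon bound to the oxygen on the aromatic ring, was already made from compound 1 to compound 3, where it gave a step that the two limits leave unreadable from compound 1 to compound 3, since both ends of that pair are limits. The data therefore offer no readable precedent for the size of this step in this assay, and no direction is indicated.

On that basis the author expects no step beyond the scatter, a 1.0-fold higher number from compound 2 to compound 4 (0.00 log units; within the scatter), and estimates compound 4 at 600000 nM, within a range from 200000 nM to 2500000 nM.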

Compound 4, half-maximal cytotoxic concentration: 1360000 nM
Estimate against measurement, compound 4: 2.3-fold (0.36 log units) below, within the range that was stated.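

In this assay, methyl in place of hydrogen on the saturated chain carbon bound to the oxygen on the aromatic ring, which turns methoxy into ethoxy, gives a 2.3-fold higher number from compound 2 to compound 4 (0.36 log units; beyond the scatter), the first readable size for this change, and a higher number means more compound is tolerated. The same change from compound 1 to compound 3 cannot be read, since both of its ends are limits of the assay. With the ethoxy group in place, 4-nitrophenyl in place of 3-nitrophenyl still goes with a lower number, an at least 1.8-fold lower number from compound 3 to compound 4 (0.26 log units; that floor lies within the scatter), but this floor alone does not establish a step beyond the scatter, and the comparison with the methoxy series stays loose: the same change on two cores in this assay, an at least 4.2-fold lower number (0.62 log units; beyond the scatter) from compound 1 to compound 2 and an at least 1.8-fold lower number (0.26 log units; that floor lies within the scatter) from compound 3 to compound 4; the limit leaves it open whether they differ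

How far compound 1 and compound 3 actually lie from compound 2 and compound 4 stays unknown, and with it the true size of the nitrophenyl step on either core: the limit of > 2500000 nM in this assay, at which 2 of the 4 values shown sit. The compounds shown also do not tell how propoxy in place of ethoxy, or an amine in place of the nitro group, would read in this assay.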